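Alpha-branching of the sulfonyl acetic acid chain

The compounds below may be only part of what the source reports. "The series", "measured", "known", "first", "only" and "open" are said of these compounds alone.

Compound 1 `COc1cc(C)c(-c2cccc(COc3ccc(S(=O)(=O)CC(=O)O)cc3)c2)c(C)c1` gives 57.5 nM in a functional assay on CHO cells for agonist activity at Free fatty acid receptor 1 (Homo sapiens), read by FLIPR and calcium flux; on this read-out lower numbers stand for an effect already at smaller amounts and higher numbers for an effect only at larger amounts of compound. Compound 2 `COc1cc(C)c(-c2cccc(COc3ccc(S(=O)(=O)C(C)C(=O)O)cc3)c2)c(C)c1` gives only > 1000 nM in this assay, which is a limit of the assay and not a number. Among the compounds with values here, the one measured step, an at least 17-fold higher number from compound 1 to compound 2 (1.24 log units; beyond the scatter), ends at the limit of > 1000 nM in this assay, at which 1 of the 2 values shown sits. Compound 3 `CCC(C(=O)O)S(=O)(=O)c1ccc(OCc2cccc(-c3c(C)cc(OC)cc3C)c2)cc1` differs from compound 2 by methyl in place of hydrogen on a saturated chain carbon, two bonds along the chain from a carbonyl carbon and a sulfonyl sulfur. This change continues in the same direction as that step, so compound 3 is expected to stay at or beyond the limit, with a step that the limit leaves unreadable from compound 2 to compound 3, and a reported value would most likely again be a limit. Compound 3 is estimated at 3000 nM, range 1000 nM to 10000 nM.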

Compound 3, half-maximal effective concentration in the Free fatty acid receptor 1 assay: > 1000 nM
Compound 3 was reported as a limit; the forecaster's own chance of this, stated with the estimate: 80%; the middle value lies beyond the limit too.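

With ethyl in place of hydrogen on the saturated chain carbon bound to a carbonyl carbon and a sulfonyl sulfur, the Free fatty acid receptor 1 assay shows an at least 17-fold higher number from compound 1 to compound 3 (1.24 log units; beyond the scatter), so the longer branch does not restore the value of compound 1, which gives 57.5 nM. Compound 3 gives > 1000 nM, which is a limit of the assay. The step from compound 2 to compound 3 cannot be read, and compound 2 and compound 3 both stand at this limit: the limit of > 1000 nM in the Free fatty acid receptor 1 assay, at which 2 of the 3 values shown sit.

Going by these compounds, how far compound 2 and compound 3 lie beyond the limit remains open. In a physicochemical assay for lipophilicity, using the shake flask method, in phosphate buffer, measured as octanol-water partition, with a stated time of 24 h, at pH 7.4, tested at 100 uM (a lower number here means a more polar compound, a higher number a more lipophilic compound), compound 2 reads "not determined" (no result reported) and compound 3 reads "not determined" (no result reported), so that assay offers no comparison. Also open, on these data alone, is how a fluorine or a hydroxyl on this chain carbon would read in the Free fatty acid receptor 1 assay.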